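This account rests on a few compounds, and the source may have more. Where it says the series, first, only, none or still open, it means among the compounds named here.

Measured so far:
compound 1, `O=S(=O)(CSc1nnc(Br)n1Cc1ccc(Br)c2ccccc12)Nc1ccc(Cl)nc1`, in an assay on HEK293 cells for inhibition of solute carrier family 22 member 12 (Homo sapiens); a lower number here means a stronger inhibitor, a higher number a weaker inhibitor: 1940 nM
compound 2, `O=S(=O)(CSc1nnc(Br)n1Cc1ccc(Br)c2ccccc12)Nc1ccc(F)nc1`, in this assay: 1550 nM

Among the measured compounds shown here, compound 2 gives the lowest of the two numbers, but its only neighbour is compound 1, and the step of a 1.3-fold lower number from compound 1 to compound 2 (0.10 log units; within the scatter) lies within the scatter, so the two cannot be ranked.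

Compound 3, `O=S(=O)(CSc1nnc(Br)n1Cc1ccc(Br)c2ccccc12)Nc1cccnc1Cl`, is not yet measured. It differs from compound 2 by 2-chloropyridin-3-yl in place of 6-fluoropyridin-3-yl on a sulfonamide nitrogen. For the measured compounds named here, the one measured step, a 1.3-fold lower number from compound 1 to compound 2 (0.10 log units; within the scatter), bears on this change only in part: it swaps the halogen on the pyridine but leaves its position on the ring unchanged, and it produced no movement beyond the scatter. Going by the values given here, the move of the halogen from the 6-position to the 2-position of the pyridin-3-yl group has no precedent. From the compounds shown here alone, the expectation for compound 3 is therefore a step of a 1.2-fold higher number from compound 2 to compound 3 (0.09 log units; within the scatter) with no clear direction beyond the scatter, with a wide range because the positional change is untested. The estimate for compound 3 in this assay is 1900 nM, between 600 nM and 6000 nM.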

Compound 3, half-maximal inhibitory concentration: 5100 nM
Beside the measured number, compound 3's estimate is 2.7-fold (0.43 log units) below it; measured number inside the range.
By their numbers in this assay, from the lowest: compounds 2 and 1 (each within the scatter of the next); then compound 3.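

In this assay, the pair of 6-chloropyridin-3-yl and 2-chloropyridin-3-yl on the sulfonamide nitrogen keeps the halogen and changes only its place on the ring, and it gives a 2.6-fold higher number from compound 1 to compound 3 (0.42 log units; beyond the scatter) as the first movement beyond the scatter in the series. The change from 6-fluoropyridin-3-yl gives a 3.3-fold higher number from compound 2 to compound 3 (0.52 log units; beyond the scatter) of similar size, so the sulfonamide nitrogen substituent responds to where the halogen stands on the pyridine, whereas the exchange of halogen alone, a 1.3-fold lower number from compound 1 to compound 2 (0.10 log units; within the scatter) with its place kept, did not separate the compounds. No supporting data bear on the reason for this rise.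

The compounds shown leave open whether the higher number follows the ring position alone or chloro at that position. A 2-fluoropyridin-3-yl group or an unsubstituted pyridin-3-yl group on the sulfonamide nitrogen would bear on that question.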